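Methoxy to Methyl: Expected Cytotoxicity of Compound 3

This account rests on a few compounds, and the source may have more. Where it says the series, first, only, none or still open, it means among the compounds named here.

Measured compounds:
compound 1 `COc1ccccc1N1CCn2c1n[nH]c(=O)c2=O` gives 26%
compound 2 `N/N=C1\NCCN1c1ccccc1` gives 0%

In an ADME assay on Vero cells (Chlorocebus sabaeus) for cytotoxicity, with a stated time of 72 h, tested at 10 ug/mL (on this read-out lower numbers stand for a weaker effect and higher numbers for a stronger effect at the one concentration tested), compound 1 gives 26%. In this assay compound 2 gives 0%. Compound 1 therefore stands highest of the two numbers, and its gap to compound 2 lies beyond the usual scatter. Compound 1 and compound 2 share no single point of difference, so their two values can only be compared, not traced to one change.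

Compound 3 `Cc1ccccc1N1CCn2c1n[nH]c(=O)c2=O` has not yet been measured. It differs from compound 1 in one place: methyl in place of methoxy on an aromatic carbon. Among the compounds with values here, no measured pair shows this kind of change, so there is no measured step to lean on. The change is small, and a small step in this assay is expected, downward if any, and not beyond the scatter.

Compound 3 is expected to give 22% in this assay, within a range from 5% to 40%. The expected step of a number 4 percentage points lower from compound 1 to compound 3 (within the scatter) is estimated to stay within the usual scatter.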

Compound 3, a percentage reported as inhibition, at one concentration (the size of the read-out at that concentration, not a potency): 0%
Estimate against measurement, compound 3: 22 percentage points above, and the stated range ends above it.
By their numbers in this assay, from the lowest: compounds 2 and 3 (each within the scatter of the next); then compound 1.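

In this assay, methyl in place of methoxy on an aromatic carbon, ortho to a large group, gives a number 26 percentage points lower from compound 1 to compound 3 (beyond the scatter) on an otherwise unchanged structure. Within the data shown here, this is the only pair here that differs in one place, and it shows that the read-out is sensitive to this position: replacing methoxy with the slightly smaller methyl is enough to produce a clear step. No measurement here explains why the read-out follows this change.

The compounds shown leave open whether the oxygen of methoxy is what matters, and a hydroxyl group or plain hydrogen on the same carbon would help to separate the oxygen from the carbon attached to it. Going by these compounds, how an amine or a longer chain such as ethoxy would read at this position also remains open.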